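The source may hold more compounds than are shown below. What is called first, only, known or untested is meant among the compounds shown, and "the series" means these compounds.

In an ADME assay on L6 cells (Rattus norvegicus) for cytotoxicity (on this read-out lower numbers stand for stronger inhibition and higher numbers for weaker inhibition), compound 1 `CN1CCN(CCC(=O)OC2CC3(N4CCCC4)CC(c4ccccc4)C2C(c2ccccc2)C3)CC1` gives 21300 nM, compound 2 `CN1CCN(CCC(=O)OC2CC3(N(C)C)CC(c4ccccc4)C2C(c2ccccc2)C3)CC1` gives 31100 nM and compound 3 `CN1CCN(CCC(=O)N2CCC3(N4CCN(C)CC4)CC(c4ccccc4)C2C(c2ccccc2)C3)CC1` gives 161000 nM. Compound 2 thus lies within the scatter of compound 1, and both lie well under compound 3. Compound 4 `CN1CCN(CCCC(=O)OC2CC3(N(C)C)CC(c4ccccc4)C2C(c2ccccc2)C3)CC1` carries one change from compound 2: (4-methylpiperazin-1-yl)methyl in place of 4-methylpiperazin-1-yl on a saturated chain carbon, two bonds along the chain from a carbonyl carbon, on a saturated chain carbon, two bonds along the chain from a carbonyl carbon. Among the measured compounds shown here, the only measured single-site step, a 1.5-fold higher number from compound 1 to compound 2 (0.16 log units; within the scatter), replaces pyrrolidin-1-yl with dimethylamino on a saturated ring carbon, so it bears only indirectly, and no measured pair varies this chain. No shift beyond the scatter is therefore expected, and the expected step is a 1.1-fold lower number from compound 2 to compound 4 (0.03 log units; within the scatter). For compound 4 the estimated value in this assay is 29000 nM, with an expected range of 12000 nM to 70000 nM.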

Compound 4, half-maximal inhibitory concentration: 19900 nM
Compound 4: the middle estimate sits 1.5-fold (0.16 log units) above what was measured; the measured number falls inside the stated range.
By their numbers in this assay, from the lowest: compounds 4, 1 and 2 (each within the scatter of the next); then compound 3.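

In this assay, (4-methylpiperazin-1-yl)methyl in place of 4-methylpiperazin-1-yl on a saturated chain carbon, two bonds along the chain from a carbonyl carbon gives a 1.6-fold lower number from compound 2 to compound 4 (0.19 log units; within the scatter) and so stays within the scatter. Among the compounds shown here, this is the first measured step in this chain, and the read-out does not separate the two chain lengths. No measured evidence bears on this result. Still open, from the compounds shown here alone, is whether a longer chain, such as 4-(4-methylpiperazin-1-yl)butyl, also stays within the scatter. Also open, going by these compounds, is whether morpholin-4-yl in place of 4-methylpiperazin-1-yl does so at this chain end.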